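A few compounds are considered here, and "the series" means these few. Any claim that something is new, unique, unknown or untested is made for them only; others in the source may bear on it.

Compound 1 `CC(/C=C/CC(C)CCCC(C)C)=C\C(=O)SC(C)C` gives 8.39 in a physicochemical assay for lipophilicity; a lower number here means a more polar compound, a higher number a more lipophilic compound.
Compound 2 `C#CCSC(=O)/C=C(C)/C=C/CC(C)CCCC(C)C` gives 5.07 in this assay.
Compound 3 `COC(C)(C)CCCC(C)C/C=C/C(C)=C/C(=O)SC(C)C` gives 7.19 in this assay.

The study turns on one change made twice: propargyl in place of isopropyl on a sulfur. Going from compound 1 to compound 2 it produced a number 3.32 log units lower from compound 1 to compound 2 (beyond the scatter). The same change, (propargyl in place of isopropyl on a sulfur), now carries compound 3 to the not yet measured compound 4 `C#CCSC(=O)/C=C(C)/C=C/CC(C)CCCC(C)(C)OC`; the place of the change is the same in both pairs. What separates the two cores is methoxy in place of hydrogen on a saturated chain carbon bound to three saturated chain carbons, and that change on its own gave a number 1.20 log units lower from compound 1 to compound 3 (beyond the scatter), so compound 3 already stands lower than compound 1 in this assay.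

For compound 4 a step of about the same size as the earlier one is expected, a number 3.29 log units lower from compound 3 to compound 4 (beyond the scatter), because a number 3.32 log units lower from compound 1 to compound 2 (beyond the scatter) came from the same change at the same place on a sulfur. Since compound 3 starts from 7.19, compound 4 is estimated to come out near 3.9, with a likely span from 3 to 4.9, before the measurement itself is known.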

Compound 4, partition coefficient: 5.9
Compound 4: the middle estimate sits 2.00 log units below what was measured, and the stated range ends below it.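

Propargyl in place of isopropyl on a sulfur lowered the number on both cores (a number 3.32 log units lower from compound 1 to compound 2 (beyond the scatter)) and (a number 1.29 log units lower from compound 3 to compound 4 (beyond the scatter)), so across these two pairs the direction carried over but the size did not. The methoxy change ran the opposite way on the two cores, giving (a number 1.20 log units lower from compound 1 to compound 3 (beyond the scatter)) but (a number 0.83 log units higher from compound 2 to compound 4 (beyond the scatter)), which shows that in these four compounds the effect of each change depended on the other, while two pairs cannot show what size the step would take on a further core. Nothing among the data shown accounts for the smaller step on the methoxy core.

The compounds shown leave open whether other groups on the sulfur, such as ethyl or benzyl, would follow the same course on both cores. They also leave open whether a hydroxy group or an amine on that saturated chain carbon would reverse direction between the cores as methoxy did.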